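The source may report more compounds than this note shows. Statements on the series, on what has been measured and on what is new or still open speak of the compounds shown alone.

Notes on the series in an ADME assay on MT4 cells (Homo sapiens) for cytotoxicity, read by MTT assay; on this read-out higher numbers stand for lower toxicity in this test and lower numbers for higher toxicity in this test. Compound 1 (`O=C1c2ccccc2C(=O)N1CCOC(=S)N(C(=O)c1ccc(F)cc1F)c1ccc(Cl)cc1`) gives 52000 nM, and compound 2 (`Cc1cc(C(=O)N(C(=S)OCCN2C(=O)c3ccccc3C2=O)c2ccc(Cl)cc2)c(C)o1`) gives 40000 nM. These two numbers lie within the scatter of each other, so compound 2 has no distinct rank on this small set.

Compound 3 (`O=C1c2ccccc2C(=O)N1CCOC(=S)N(C(=O)c1ccc2ccccc2c1)c1ccc(Cl)cc1`) has naphthalen-2-yl in place of 2,5-dimethylfuran-3-yl on a carbonyl carbon.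

Going by the values given here, only one measured step bears on this change. It is the exchange of 2,4-difluorophenyl for 2,5-dimethylfuran-3-yl on the same carbonyl carbon, a 1.3-fold lower number from compound 1 to compound 2 (0.11 log units; within the scatter), and it stays within the scatter. That single step is thin evidence, and naphthalen-2-yl itself has no measurement in this series. Even so, with only that small step as a guide, no shift beyond the scatter is expected in this assay, and no direction is favoured. The expected step is no change at the digits printed from compound 2 to compound 3 (within the scatter). The estimated value for compound 3 is 40000 nM, with an expected range of 15000 nM to 100000 nM.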

Compound 3, half-maximal cytotoxic concentration: 37000 nM
Compound 3: the middle estimate sits 1.1-fold (0.03 log units) above what was measured, and the stated range covers the measured number.
By their numbers in this assay, from the lowest: compounds 3, 2 and 1 (each within the scatter of the next).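

At the carbonyl carbon whose other neighbour is the amide-type nitrogen, this assay gives a 1.1-fold lower number from compound 2 to compound 3 (0.03 log units; within the scatter) for naphthalen-2-yl in place of 2,5-dimethylfuran-3-yl, and a 1.4-fold lower number from compound 1 to compound 3 (0.15 log units; within the scatter) for naphthalen-2-yl in place of 2,4-difluorophenyl. The earlier pair set only 2,5-dimethylfuran-3-yl against 2,4-difluorophenyl; this result adds a group with 10 heavy atoms, 2 six-membered aromatic rings of carbon only and 0 hydrogen-bond acceptors, and all three compounds still lie within the scatter of one another, so this read-out does not separate these three groups at this position. No measurement is available that would account for this result.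

Going by these compounds, all three groups at this carbonyl carbon are aromatic, so it remains open whether an amine such as piperidin-1-yl, a carboxylic acid or a longer alkyl chain there would shift the number beyond the scatter. The rest of the shared core is the same in compounds 1, 2 and 3, so these data say nothing about changes elsewhere in the molecule.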